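Compound 3 to compound 4: replacing diisopropylamino

The compounds below may be only part of what the source reports. "The series", "measured", "known", "first", "only" and "open" are said of these compounds alone.

Of the compounds shown here, three on a shared core have been read in a functional assay on Huh-7 cells (Homo sapiens) for cytotoxicity, read by MTT assay, with a stated time of 3 days (a higher number here means that more compound is tolerated, a lower number that less compound is tolerated), so far. Compound 1 `OC[C@H]1O[C@@H](n2cnc3c(CSCc4ccccc4)ncnc32)[C@H](O)[C@@H]1O` gives only a limit, > 100000 nM, and no number. Compound 2 `OC[C@H]1O[C@@H](n2cnc3c(COc4ccccn4)ncnc32)[C@H](O)[C@@H]1O` also gives only a limit, > 250000 nM, and no number. Among the measured compounds shown here, compound 3 `CC(C)N(Cc1ncnc2c1ncn2[C@@H]1O[C@H](CO)[C@@H](O)[C@H]1O)C(C)C` gives 18000 nM, the only true number, and so the one firm reference point.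

Compound 4 `O=C(O)CSCc1ncnc2c1ncn2[C@@H]1O[C@H](CO)[C@@H](O)[C@H]1O` carries (carboxymethyl)sulfanyl in place of diisopropylamino on a saturated chain carbon bound to an aromatic carbon, with the rest unchanged.

For the measured compounds named here, two measured steps bear on this change: an at least 5.5-fold lower number from compound 1 to compound 3 (0.74 log units; beyond the scatter) and an at least 13-fold lower number from compound 2 to compound 3 (1.14 log units; beyond the scatter). Read backwards, both show a higher number once diisopropylamino is gone. Compound 1 is the closer guide, since it also has a sulfanyl group at that place.

A rise in this assay is therefore expected, not a change within the scatter. The expected change is an 8.3-fold higher number from compound 3 to compound 4 (0.92 log units; beyond the scatter) in this read-out. For compound 4 the estimate is 150000 nM, with an expected range from 60000 nM to 300000 nM, and a report of only a limit would not surprise.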

Compound 4, half-maximal cytotoxic concentration: > 100000 nM
Compound 4: a limit, no number; the forecaster's own chance of this, stated with the estimate: 60%; the middle value does not contradict the limit.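

In this assay, among the compounds shown here, the change gives an at least 5.5-fold higher number from compound 3 to compound 4 (0.74 log units; beyond the scatter), so a group ending in a carboxy also moves the read-out away from compound 3, and compound 3 remains the only compound with a true number. Compound 4 gives only a limit, > 100000 nM. Compound 1 sits at the same limit, so carboxy in place of phenyl on a saturated chain carbon bound to a sulfur has no readable size, and neither step to compound 4, from compound 1 or from compound 2, can be read: the limit of > 100000 nM in this assay, at which 2 of the 4 values shown sit.

Still open, from the compounds shown here alone, is whether the lower number belongs to diisopropylamino alone or to amines at this place more widely, which a smaller amine such as dimethylamino would test. Going by these compounds, how far compound 1, compound 2 and compound 4 lie beyond their limits also remains open.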